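Trading bromines for methoxy groups on the hydroxyphenyl ring

This account rests on a few compounds, and the source may have more. Where it says the series, first, only, none or still open, it means among the compounds named here.

compound 1 `COc1cc(/C=C/C(=O)Nc2cc3c(Nc4ccc(F)c(Cl)c4)ncnc3cc2O[C@H]2CCOC2)cc(OC)c1OC` gives 4150 nM
compound 2 `O=C(/C=C/c1cc(Br)c(O)c(Br)c1)Nc1cc2c(Nc3ccc(F)c(Cl)c3)ncnc2cc1O[C@H]1CCOC1` gives 28800 nM
compound 3 `COc1cc(/C=C/C(=O)Nc2cc3c(Nc4ccc(F)c(Cl)c4)ncnc3cc2OC)cc(OC)c1` gives "not active" (no number reported)

In a functional assay on A549 cells (Homo sapiens) for cytotoxicity, read by MTT assay, with a stated time of 72 h (on this read-out higher numbers stand for weaker inhibition and lower numbers for stronger inhibition), compound 2 gives 28800 nM as the higher of the two numbers, which marks it as the weaker inhibitor of the pair, and compound 3 gave no number. Compound 4 `COc1cc(/C=C/C(=O)Nc2cc3c(Nc4ccc(F)c(Cl)c4)ncnc3cc2O[C@H]2CCOC2)cc(OC)c1O` is still unmeasured and differs from compound 2 in one group (4-hydroxy-3,5-dimethoxyphenyl in place of 3,5-dibromo-4-hydroxyphenyl on a double-bonded chain carbon bound to a double-bonded chain carbon). Among the measured compounds shown here, one measured step bears on this: a 6.9-fold higher number from compound 1 to compound 2 (0.84 log units; beyond the scatter) when 3,5-dibromo-4-hydroxyphenyl replaced 3,4,5-trimethoxyphenyl, a modest step beyond the scatter. Compound 1 at 4150 nM also carries methoxy groups, so compound 4 is expected to land nearer to it and much of that step should be undone. In this assay a fall is expected, with a 4.8-fold lower number from compound 2 to compound 4 (0.68 log units; beyond the scatter) as the estimated step. Compound 4 is estimated at 6000 nM (range 2000 nM to 18000 nM).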

Compound 4, half-maximal inhibitory concentration: 27000 nM
Estimate against measurement, compound 4: 4.5-fold (0.65 log units) below, and the stated range ends below it.
By their numbers in this assay, from the lowest: compound 1; then compounds 4 and 2 (each within the scatter of the next).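

In this assay, two methoxy groups in place of the two bromines give a 1.1-fold lower number from compound 2 to compound 4 (0.03 log units; within the scatter), so at this position the change makes no measurable difference while the hydroxyl stays. Hydrogen in place of methyl on that oxygen gives a 6.5-fold higher number from compound 1 to compound 4 (0.81 log units; beyond the scatter), so here the hydroxyl marks the weaker compound whichever groups flank it, though compound 3 also lacks a hydroxyl and gave no number. Nothing measured here explains this.

As far as these compounds go, whether the bromines combined with a methoxy group in place of the hydroxyl would also give a lower number remains open, as does how an amine in place of the hydroxyl would behave.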